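Heteroaryl amide swaps on the shared core

The source may report more compounds than this note shows. Statements on the series, on what has been measured and on what is new or still open speak of the compounds shown alone.

Values in a functional assay on BSY-1 cells (Homo sapiens) for inhibition, read by colorimetric assay and sulforhodamine B assay, with a stated time of 48 h (a higher number here means a weaker inhibitor of growth, a lower number a stronger inhibitor of growth), are as follows:
- compound 1 `CCCCCCCCCCCC[C@@H](O)[C@H]1CC[C@H]([C@H](O)CCCCCCCCCCNC(=O)c2cncs2)O1` gives 3980 nM
- compound 2 `CCCCCCCCCCCC[C@@H](O)[C@H]1CC[C@H]([C@H](O)CCCCCCCCCCNC(=O)c2ccsc2)O1` gives 3020 nM
- compound 3 `CCCCCCCCCCCC[C@@H](O)[C@H]1CC[C@H]([C@H](O)CCCCCCCCCCNC(=O)c2ccnn2C)O1` is not yet measured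

Among the compounds with values here, compound 2 stands within the scatter of compound 1, the only other measured compound. The change to compound 3 is 1-methyl-1H-pyrazol-5-yl in place of thiophen-3-yl on a carbonyl carbon, with 1-methyl-1H-pyrazol-5-yl in place of thiophen-3-yl on a carbonyl carbon. Within the data shown here, the one measured step at this place, a 1.3-fold lower number from compound 1 to compound 2 (0.12 log units; within the scatter), stays within the scatter, so no step beyond the scatter is expected in this assay, although a single step is thin evidence. The estimated change, a 1.2-fold higher number from compound 2 to compound 3 (0.06 log units; within the scatter), is correspondingly small. Compound 3 is estimated at 3500 nM, with an expected range from 1500 nM to 8000 nM for the measurement.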

Compound 3, concentration for 50% growth inhibition: 10 nM
Compound 3: the middle estimate sits 350-fold (2.54 log units) above what was measured; measured number outside the range, below it.
By their numbers in this assay, from the lowest: compound 3; then compounds 2 and 1 (each within the scatter of the next).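

In this assay, within the data shown here, the group on the amide carbonyl is not a silent position: 1-methyl-1H-pyrazol-5-yl in place of thiophen-3-yl gives a 300-fold lower number from compound 2 to compound 3 (2.48 log units; beyond the scatter) and in place of 1,3-thiazol-5-yl gives a 400-fold lower number from compound 1 to compound 3 (2.60 log units; beyond the scatter) while the one earlier swap stayed within the scatter. The result therefore separates 1-methyl-1H-pyrazol-5-yl from both sulfur-containing rings on the shared core. No available evidence explains the gain.

Still open, going by these compounds, is whether 1H-pyrazol-5-yl without the methyl, or 1-ethyl-1H-pyrazol-5-yl, would keep the low number of compound 3. On these data alone, whether 1-methyl-1H-imidazol-5-yl would do the same is also open.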